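Removing the Methyl from the Ring of Compound 3

A few compounds are considered here, and "the series" means these few. Any claim that something is new, unique, unknown or untested is made for them only; others in the source may bear on it.

Three compounds share one core and differ only in the group on the aromatic nitrogen. In a functional assay on HepG2 cells (Homo sapiens) for inhibition, read by MTT assay, with a stated time of 24 h (on this read-out higher numbers stand for weaker inhibition and lower numbers for stronger inhibition), compound 1 `Cc1ccccc1-n1cc(CN2C(=O)C[C@@H]3CC[C@@]2(C)C3(C)C)nn1` gives 150 nM, compound 2 `COc1ccccc1-n1cc(CN2C(=O)C[C@@H]3CC[C@@]2(C)C3(C)C)nn1` gives 110 nM, and compound 3 `Cc1ccc(-n2cc(CN3C(=O)C[C@@H]4CC[C@@]3(C)C4(C)C)nn2)cc1` gives 480 nM, the highest number of the three. The step of a 3.2-fold higher number from compound 1 to compound 3 (0.51 log units; beyond the scatter) and the step of a 4.4-fold higher number from compound 2 to compound 3 (0.64 log units; beyond the scatter) lie beyond the scatter, while a 1.4-fold lower number from compound 1 to compound 2 (0.13 log units; within the scatter) lies within it. Compound 4 `CC1(C)[C@H]2CC[C@]1(C)N(Cc1cn(-c3ccccc3)nn1)C(=O)C2` differs from compound 3 by hydrogen in place of methyl on an aromatic carbon. Among the measured compounds shown here, no measured step removes a substituent outright; the measured steps compare one substituent with another or its placement, so they bear on this change only indirectly. A step within the scatter is therefore expected, a 1.2-fold lower number from compound 3 to compound 4 (0.08 log units; within the scatter). Compound 4 is estimated at 400 nM, within a range from 180 nM to 900 nM.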

Compound 4, half-maximal inhibitory concentration: 90 nM
Compound 4: the middle estimate sits 4.4-fold (0.65 log units) above what was measured, and the stated range ends above it.
By their numbers in this assay, from the lowest: compounds 4, 2 and 1 (each within the scatter of the next); then compound 3.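

In this assay the step of a 5.3-fold lower number from compound 3 to compound 4 (0.73 log units; beyond the scatter) lies beyond the scatter, so at this place, para to a large group, the methyl goes with the higher number of compound 3. Compound 4, with no substituent on its ring, sits with compound 1 and compound 2: the steps of a 1.2-fold lower number from compound 2 to compound 4 (0.09 log units; within the scatter) and a 1.7-fold lower number from compound 1 to compound 4 (0.22 log units; within the scatter) lie within the scatter, and among these four compounds only the 4-methylphenyl stands apart.

Going by these compounds, whether an amine or a longer chain at the same place would also give a higher number stays open. Nothing shown here offers an explanation for the effect of the methyl.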